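Replacing a propyl with 2-methylphenyl in a weak carbamate

The source may hold more compounds than are shown below. What is called first, only, known or untested is meant among the compounds shown, and "the series" means these compounds.

Compound 2 `CCCCNC(=O)Oc1ccc(C2=NCCO2)cc1` gives 34000 nM in an assay on cell membranes (strain Wistar) for inhibition of Monoglyceride lipase (Rattus norvegicus), read by HPLC (on this read-out higher numbers stand for weaker inhibition and lower numbers for stronger inhibition), and compound 1 `Cc1ccccc1CNC(=O)Oc1ccc(C2=NCCS2)cc1` gives 46000 nM, a pair of numbers within the scatter of each other. Compound 3 `Cc1ccccc1CNC(=O)Oc1ccc(C2=NCCO2)cc1` differs from compound 2 by 2-methylphenyl in place of propyl on a saturated chain carbon bound to an amide-type nitrogen. Going by the values given here, no measured pair shows this change, and compound 1 carries the same 2-methylphenyl group with a weak value of its own, so no step beyond the scatter is expected in this assay. Compound 3 is therefore estimated at 40000 nM, with a range of 15000 nM to 110000 nM, a step of a 1.2-fold higher number from compound 2 to compound 3 (0.07 log units; within the scatter) that is expected to stay within the scatter.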

Compound 3, half-maximal inhibitory concentration: 35000 nM
Beside the measured number, compound 3's estimate is 1.1-fold (0.06 log units) above it, and the stated range covers the measured number.
By their numbers in this assay, from the lowest: compounds 2, 3 and 1 (each within the scatter of the next).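

In this assay, 2-methylphenyl in place of propyl on the saturated chain carbon bound to an amide-type nitrogen leaves the number unchanged (a 1.0-fold higher number from compound 2 to compound 3 (0.01 log units; within the scatter)), so this position takes the larger group with no step beyond the scatter. The oxygen-bearing five-membered ring in place of the sulfur-bearing one, on an aromatic carbon, also stays within the scatter (a 1.3-fold lower number from compound 1 to compound 3 (0.12 log units; within the scatter)). No measurement here offers a reason for either result.

Still open, from the compounds shown here alone, is whether an amine or a carboxylic acid at this position would move the number beyond the scatter.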